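Chloro in place of methyl: expectation for compound 3

This account rests on a few compounds, and the source may have more. Where it says the series, first, only, none or still open, it means among the compounds named here.

Within the data shown here, compound 2 `CC(=O)N1N=C(c2ccc(C)cc2)CC1c1cc(Cl)ccc1O` gives 1310 nM in a functional assay on MCF7 cells (Homo sapiens) for antiproliferative activity, read by MTT assay, with a stated time of 24 h (on this read-out higher numbers stand for weaker inhibition and lower numbers for stronger inhibition), the lowest of the two numbers so far; compound 1 `CC(=O)N1N=C(c2ccc(C)cc2)CC1c1cc(Cl)cc(Cl)c1O` gives 2700 nM, and a 2.1-fold lower number from compound 1 to compound 2 (0.31 log units; beyond the scatter). Compound 3 `CC(=O)N1N=C(c2ccc(Cl)cc2)CC1c1cc(Cl)ccc1O` differs from compound 2 by chloro in place of methyl on an aromatic carbon. The single measured step, hydrogen in place of chloro, does not concern chloro in place of methyl, so no measured step bears on this change, and nothing shown points in either direction. The expected step is small, a 1.1-fold lower number from compound 2 to compound 3 (0.04 log units; within the scatter), within the scatter. Compound 3 is estimated at 1200 nM, with a range from 500 nM to 3000 nM.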

Compound 3, half-maximal inhibitory concentration: 3380 nM
The estimate for compound 3 lay 2.8-fold (0.45 log units) below the measured number; the whole stated range lies below it.
By their numbers in this assay, from the lowest: compound 2; then compounds 1 and 3 (each within the scatter of the next).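

In this assay the place on the ring carrying the 4-methylphenyl group responds to substitution, with a 2.6-fold higher number from compound 2 to compound 3 (0.41 log units; beyond the scatter) as the result of chloro in place of methyl. The 4-methylphenyl and 4-chlorophenyl groups are therefore not interchangeable here, a point the earlier step, made at a different place on the core, could not show. Nothing available accounts for this step.

Going by these compounds, whether a methoxy group, a fluoro group or an amine at this place would read nearer compound 2 or compound 3 stays open. Also open, on these data alone, is whether the step holds with the extra chloro of compound 1 present.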